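This account rests on a few compounds, and the source may have more. Where it says the series, first, only, none or still open, it means among the compounds named here.

Measured so far:
compound 1, `CCN(c1nc(C)cc(C)n1)c1ccc(OC)cc1SC`, in an assay on isolated protein for binding affinity to corticotropin-releasing factor receptor 1 (Homo sapiens) (a lower number here means a stronger inhibitor, a higher number a weaker inhibitor), gives 60 nM
compound 2, `CCN(c1nc(C)cc(C)n1)c1c(Br)cc(C(C)C)cc1SC`, in this assay gives 51 nM

Compound 2 shows the lowest of the two numbers, and compound 1 sits close to it, within the scatter. Within the data shown here, the two differ in more than one place, so no single step between them can be read off. Compound 3, `CCN(c1nc(C)cc(C)n1)c1ccc(C(C)C)cc1SC`, is not yet measured. It differs from compound 2 by hydrogen in place of bromo on an aromatic carbon. Among the measured compounds shown here, no measured pair shows this change, so the step of a 1.4-fold higher number from compound 2 to compound 3 (0.14 log units; within the scatter) is expected to be small, with no confident direction. Compound 3 is estimated at 70 nM, with a range from 25 nM to 200 nM.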

Compound 3, inhibition constant: 36 nM
Estimate against measurement, compound 3: 1.9-fold (0.29 log units) above; low and high end bracket the measured number.
By their numbers in this assay, from the lowest: compounds 3, 2 and 1 (each within the scatter of the next).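

With hydrogen in place of bromo on this aromatic carbon, the result is a 1.4-fold lower number from compound 2 to compound 3 (0.15 log units; within the scatter) and the bromo can therefore be dropped with no measurable loss in this assay for this pair. Isopropyl in place of methoxy on an aromatic carbon gives a 1.7-fold lower number from compound 1 to compound 3 (0.22 log units; within the scatter) and so these two groups cannot be told apart here either. Nothing at hand explains why these numbers stay so close. Still open, going by these compounds, is whether an amine, a chloro or a carboxylic acid on the bromo-bearing carbon would move the number beyond the scatter. On these data alone, a longer chain in place of isopropyl remains equally open.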